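Trifluoromethyl for Fluoro in a Channel Activator Series

The source may report more compounds than this note shows. Statements on the series, on what has been measured and on what is new or still open speak of the compounds shown alone.

Four compounds share the same amide-linked core. Compound 1 `O=C(Cn1nnc(-c2ccccc2)n1)NC1CC2CCC1C2` carries a bicyclic amine at the amide. Compound 2 `Cc1nc(NC(=O)Cn2nnc(-c3ccccc3)n2)n(-c2ccccc2)n1` and compound 3 `Cc1cc(NC(=O)Cn2nnc(-c3cccc(F)c3)n2)n(C2CCCCC2)n1` carry aromatic amines, and compound 3 also bears a fluoro group on the phenyl at the far end. Compound 4 `Cc1cc(NC(=O)Cn2nnc(-c3cccc(C(F)(F)F)c3)n2)n(C2CCCCC2)n1` is the one not yet measured.

The read-out is an assay on HEK293 cells for activation of Kir3.1/Kir3.2 (Homo sapiens), read by thallium flux; a lower number here means a smaller maximal response, a higher number a larger maximal response. In this assay compound 1 gives 13%, while compound 2 is reported as "not active" (no number reported) with no number. Going by the values given here, compound 3 gives 96%, the highest of the two numbers known here; compound 1 sits far lower, a gap well beyond the scatter of repeated runs.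

Compound 4 differs from compound 3 by trifluoromethyl in place of fluoro on an aromatic carbon. Among the compounds with values here, no measured pair in this set shows what such a swap does on its own, so the direction of the step is uncertain. Given the large response of compound 3 at 96%, a modest step is expected, from compound 3 to compound 4 a number 11 percentage points lower from compound 3 to compound 4 (beyond the scatter), most likely within or just beyond the scatter. Compound 4 is therefore estimated to give 85% in this assay, within a range from 50% to 110%.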

Compound 4, largest response reached (Emax), in percent of the reference or control that the assay uses: 86%
Compound 4: middle estimate off by 1 percentage points, on the low side; the measured number falls inside the stated range.
By their numbers in this assay, from the lowest: compound 1; then compounds 4 and 3 (each within the scatter of the next).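

In this assay, going by these compounds alone, putting trifluoromethyl in place of fluoro on an aromatic carbon gives a number 10 percentage points lower from compound 3 to compound 4 (within the scatter), and this is the first step in the set that changes only one place in the molecule. It shows that the 3-fluorophenyl can become a 3-(trifluoromethyl)phenyl, growing from 1 heavy atom to 4 heavy atoms with no hydrogen-bond donor or acceptor on either group, while the maximal response stays within the usual scatter. Nothing available here explains why the two groups read alike.

Still open, going by these compounds, is whether a group of another kind on this same aromatic carbon, such as an amine, a carboxylic acid or a methoxy group, would keep the response, and whether a plain phenyl would do so without any added group. Also open, on these data alone, is how much of the response comes from the far phenyl and how much from the amine side of the amide, since compound 1 and compound 2 each differ from compound 3 in more than one place and those steps cannot be read.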